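Swapping a cyclohexyl for a benzyl on the ring nitrogen

This account rests on a few compounds, and the source may have more. Where it says the series, first, only, none or still open, it means among the compounds named here.

Compound 1 `CCCCNc1cc(-c2ccccc2)nc2cc(OC)cc(OC)c12` and compound 2 `COc1cc(OC)c2c(NC3CCCCC3)cc(-c3ccccc3)nc2c1` share one core and differ only in the group on the nitrogen on an aromatic ring. In a functional assay on LN-229 cells (Homo sapiens) for inhibition, read by MTT assay, with a stated time of 72 h (a lower number here means a stronger inhibitor, a higher number a weaker inhibitor), compound 1 gives 3920 nM, and compound 2 gives 6080 nM; the step of a 1.6-fold higher number from compound 1 to compound 2 (0.19 log units; within the scatter) is within the scatter, so the two numbers cannot be told apart. Compound 3 `COc1cc(OC)c2c(NCc3ccccc3)cc(-c3ccccc3)nc2c1` carries the change (benzyl in place of cyclohexyl on a nitrogen on an aromatic ring). Going by the values given here, no measured step bears directly on this swap, and the only comparable step stayed within the scatter, so compound 3 is expected to give a number close to compound 2, about 5000 nM (from 2000 nM to 15000 nM), an expected step of a 1.2-fold lower number from compound 2 to compound 3 (0.08 log units; within the scatter).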

Compound 3, half-maximal inhibitory concentration: 7150 nM
Compound 3: the middle estimate sits 1.4-fold (0.16 log units) below what was measured; the measured number falls inside the stated range.
By their numbers in this assay, from the lowest: compounds 1, 2 and 3 (each within the scatter of the next).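

In this assay, swapping a saturated ring for an aromatic one on this nitrogen leaves the result within the scatter, at a 1.2-fold higher number from compound 2 to compound 3 (0.07 log units; within the scatter). The open-chain butyl cannot be told apart from benzyl either, at a 1.8-fold higher number from compound 1 to compound 3 (0.26 log units; within the scatter). Butyl, cyclohexyl and benzyl therefore cannot be separated at this position, and nothing available explains this. Still open, going by these compounds, is whether a group of a different kind on this nitrogen, such as an aminoethyl chain or a carboxylic acid, would move the number beyond the scatter.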